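Hydroxy to Methoxy on the Shared Core of Compound 1

This account rests on a few compounds, and the source may have more. Where it says the series, first, only, none or still open, it means among the compounds named here.

Compound 1 `O=C(Nc1cccc(-n2cc(-c3ccncc3)c(-c3cc(O)cc(Cl)c3)n2)c1)Nc1ccc(Cl)c(C(F)(F)F)c1` is the stronger of the two measured compounds: in a functional assay on MDA-MB-231 cells (Homo sapiens) for inhibition, read by sulforhodamine B assay, with a stated time of 48 h, tested at 100 uM (on this read-out lower numbers stand for a stronger effect and higher numbers for a weaker effect at the one concentration tested), compound 1 gives -38%, the lowest of the two numbers. For the measured compounds named here, its nearest neighbour is compound 2 `O=C(Nc1cccc(-n2cc(-c3ccncc3)c(-c3cc(O)cc(Cl)c3)n2)c1)Nc1ccc(Cl)c(Cl)c1`, which in this assay gives -24%; the single step between them, chloro in place of trifluoromethyl on an aromatic carbon, reads a number 14 percentage points higher from compound 1 to compound 2 (beyond the scatter).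

Compound 3 `COc1cc(Cl)cc(-c2nn(-c3cccc(NC(=O)Nc4ccc(Cl)c(C(F)(F)F)c4)c3)cc2-c2ccncc2)c1` keeps the trifluoromethyl of compound 1 and differs from it only at the phenol: methyl in place of hydrogen on an oxygen on an aromatic ring. Going by the values given here, no measured step touches this position, and the one step on record, a number 14 percentage points higher from compound 1 to compound 2 (beyond the scatter), concerns another group altogether, so it gives no direct guide. Compound 3 is therefore expected to stay close to compound 1, with a step of a number 6 percentage points higher from compound 1 to compound 3 (within the scatter), which is expected to lie within the scatter. The estimate for compound 3 is -32%, in the range from -60% to -5%.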

Compound 3, a percentage reported as activity, at one concentration (the size of the read-out at that concentration, not a potency): -88%
Compound 3: the middle estimate sits 56 percentage points above what was measured, outside the stated range (below it).
By their numbers in this assay, from the lowest: compound 3; then compound 1; then compound 2.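

For the compounds shown here, the phenol oxygen of the shared core, which no earlier step had touched, proves to be a sensitive place: in this assay, hydroxy to methoxy gives a number 50 percentage points lower from compound 1 to compound 3 (beyond the scatter). With only one heavy atom added, this step is larger than the one at the trifluoromethyl, a number 14 percentage points higher from compound 1 to compound 2 (beyond the scatter), and it shows that the free hydroxy is not required for a strong read-out at the one concentration tested. Nothing available here accounts for the size of this step.

The compounds shown leave open whether a longer chain on that oxygen, such as ethyl, would take the read-out further than methyl does, or whether an amine in place of the hydroxy would match it. They also leave open whether methoxy would bring a similar step on the core of compound 2, which carries chloro in place of trifluoromethyl.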